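A few compounds are considered here, and "the series" means these few. Any claim that something is new, unique, unknown or untested is made for them only; others in the source may bear on it.

Measured compounds:
compound 1, `COc1cc(-n2cnc3ccc(-c4ccc(C(C)=O)cc4)cc32)cc(OC)c1OC`, 450 nM
compound 2, `COc1cc(-n2cnc3ccc(-c4ccc(C)cc4F)cc32)cc(OC)c1OC`, 5650 nM
compound 3, `COc1cc(-n2cnc3ccc(-c4cccc([N+](=O)[O-])c4)cc32)cc(OC)c1OC`, 380 nM

In a functional assay on SGC-7901 cells (Homo sapiens) for antiproliferative activity, read by MTT assay, with a stated time of 72 h (a higher number here means a weaker inhibitor, a lower number a stronger inhibitor), compound 2 gives 5650 nM, the highest number of the three. The step of a 13-fold higher number from compound 1 to compound 2 (1.10 log units; beyond the scatter) and the step of a 15-fold lower number from compound 2 to compound 3 (1.17 log units; beyond the scatter) both lie beyond the scatter, so compound 2 is the weakest inhibitor among the measured compounds, while compound 1 and compound 3 sit within the scatter of each other, as a 1.2-fold lower number from compound 1 to compound 3 (0.07 log units; within the scatter) shows.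

Compound 4, `COc1cc(-n2cnc3ccc(-c4ccc(Cl)cc4Cl)cc32)cc(OC)c1OC`, differs from compound 2 in one place: 2,4-dichlorophenyl in place of 2-fluoro-4-methylphenyl on an aromatic carbon. Both measured steps that touch the 2-fluoro-4-methylphenyl group gave large drops in number, but each of them brought in a 4-acetylphenyl or a 3-nitrophenyl group, whereas the entering 2,4-dichlorophenyl stays closer in substitution pattern to the leaving group. Within the data shown here, no measured step shows a halogen-for-halogen swap of this kind, so the expectation is uncertain. Compound 4 is expected to give about 2500 nM in this assay. The range for compound 4 is estimated as 600 nM to 9000 nM. That estimate means an expected step of a 2.3-fold lower number from compound 2 to compound 4 (0.35 log units; beyond the scatter), modest and possibly within the scatter.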

Compound 4, half-maximal inhibitory concentration: > 10000 nM
Compound 4: no number, only a limit; the forecaster's own chance of this, stated with the estimate: 5%; at least 4.0-fold (0.60 log units) between middle value and limit.
By their numbers in this assay, from the lowest: compounds 3 and 1 (each within the scatter of the next); then compound 2. At a limit, above all of these: compound 4.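

In this assay compound 4 gives > 10000 nM, which is a limit of the assay and not a number: the limit of > 10000 nM in this assay, at which 1 of the 4 values shown sits. Putting 2,4-dichlorophenyl in place of 2-fluoro-4-methylphenyl gives an at least 1.7-fold higher number from compound 2 to compound 4 (0.24 log units; that floor lies within the scatter), so this change does not clearly separate the two compounds. The gaps to the other two groups are wide, at an at least 26-fold higher number from compound 3 to compound 4 (1.42 log units; beyond the scatter) and an at least 22-fold higher number from compound 1 to compound 4 (1.34 log units; beyond the scatter), so at this position 2,4-dichlorophenyl stays with 2-fluoro-4-methylphenyl at the weak end and recovers none of the activity seen with 4-acetylphenyl and 3-nitrophenyl.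

From the compounds shown here alone, how far compound 4 lies beyond its limit remains unknown, and so does whether it truly differs from compound 2. Also open is where a phenyl ring carrying only a single chlorine, or an amine or a carboxylic acid, would fall among these groups.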